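The compounds below may be only part of what the source reports. "The series", "measured", "known", "first", "only" and "open" are said of these compounds alone.

Measured compounds in hand:
compound 1 `COc1cccc2cc(C(=O)O)cnc12` — 25 mg/kg
compound 2 `COc1cccc2cc(-c3nn[nH]n3)cnc12` — 2.5 mg/kg
compound 3 `O=C(O)c1cnc2cc(C(F)(F)F)ccc2c1` — > 25 mg/kg, a limit only

In a functional assay on the whole organism (strain Sprague-Dawley) for inhibition, with Rattus norvegicus as the target (a higher number here means that more compound is needed for the effect, a lower number that less compound is needed), compound 1 gives 25 mg/kg and compound 2 gives 2.5 mg/kg. The change between them is 2H-tetrazol-5-yl in place of carboxy on an aromatic carbon; it produced a 10-fold lower number from compound 1 to compound 2 (1.00 log units; beyond the scatter). For compound 3 only a limit of this assay is known, > 25 mg/kg, and no number. How the core of compound 3 differs from the core of compound 1 is not broken down here.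

Compound 4 `FC(F)(F)c1ccc2cc(-c3nn[nH]n3)cnc2c1` has not yet been measured in this assay. It differs from compound 3 by 2H-tetrazol-5-yl in place of carboxy on an aromatic carbon; this is the same change as from compound 1 to compound 2, at a place described in the same words, so the change occurs twice among these four compounds. The expectation for compound 4 in this assay is a step of about an at least 3.1-fold lower number from compound 3 to compound 4 (0.49 log units; beyond the scatter), resting on a 10-fold lower number from compound 1 to compound 2 (1.00 log units; beyond the scatter), but since compound 3 shows only a limit, the starting point is uncertain. Compound 4 is estimated at 8 mg/kg, with a range from 2.5 mg/kg to 25 mg/kg.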

Compound 4, minimum effective dose: < 10 mg/kg
Compound 4 ended at the assay's limit; the forecaster's own chance of this, stated with the estimate: 35%; the middle value does not contradict the limit.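

Putting 2H-tetrazol-5-yl in place of carboxy on an aromatic carbon goes with a lower number in this assay on both cores, and the direction of the change carries from the core of compound 1 to the core of compound 3: the same change on two cores in this assay, a 10-fold lower number (1.00 log units; beyond the scatter) from compound 1 to compound 2 and an at least 2.5-fold lower number (0.39 log units; beyond the scatter) from compound 3 to compound 4; the limit leaves it open whether they differ

On the second core, an at least 2.5-fold lower number from compound 3 to compound 4 (0.39 log units; beyond the scatter) joins two limits of the assay rather than two numbers, which gives only a bound on the size of the step and not the size itself. Two cores also show nothing about how the change would behave on any further core, and the data do not establish that the step has the same size on both.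

Exact numbers for compound 3 and compound 4 would be needed before the two steps could be compared in size. Also open, on these data alone, is whether an amide or a sulfonic acid in place of carboxy would go the same way, and whether the step holds on a core bearing a chlorine or a longer chain instead of methoxy or trifluoromethyl.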